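Aryloxymethyl ketone series: pyridinyl to pyrimidinyl ether

A few compounds are considered here, and "the series" means these few. Any claim that something is new, unique, unknown or untested is made for them only; others in the source may bear on it.

Three members of the series have been taken through a functional assay on Jurkat cells (Homo sapiens) for inhibition; on this read-out lower numbers stand for stronger inhibition and higher numbers for weaker inhibition. Compound 1 `CC(C)[C@H](NC(=O)COc1cccc2ccccc12)C(=O)N[C@@H](CC(=O)O)C(=O)CSc1nc[nH]n1` carries a (1H-1,2,4-triazol-3-yl)sulfanyl group on the saturated chain carbon bound to the carbonyl carbon; in this assay compound 1 gives only a limit of > 200000 nM. Compound 2 `CC(C)[C@H](NC(=O)COc1cccc2ccccc12)C(=O)N[C@@H](CC(=O)O)C(=O)COc1nc2ccccc2[nH]1` bears (1H-benzimidazol-2-yl)oxy at the same place; in this assay compound 2 likewise gives only a limit of > 200000 nM. Compound 3 `CC(C)[C@H](NC(=O)COc1cccc2ccccc12)C(=O)N[C@@H](CC(=O)O)C(=O)COc1ccccn1` has (pyridin-2-yl)oxy there; in this assay compound 3 also gives only a limit of > 200000 nM. The steps between these members are therefore not readable: a step that the two limits leave unreadable from compound 1 to compound 2, a step that the two limits leave unreadable from compound 1 to compound 3, and a step that the two limits leave unreadable from compound 2 to compound 3. All that is known is the limit of > 200000 nM in this assay, at which 3 of the 3 values shown sit, so compound 3 stands at the same limit as the other two, with no ordering among them.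

Compound 4 `CC(C)[C@H](NC(=O)COc1cccc2ccccc12)C(=O)N[C@@H](CC(=O)O)C(=O)COc1ccncn1` differs from compound 3 by pyrimidin-4-yl in place of pyridin-2-yl on an oxygen on a saturated carbon. Going by the values given here, no measured step touches the pyridin-2-yl group directly; the three exchanges at this position all ended at the limit, so there is no measured ring exchange here that produced a readable number.

In this assay compound 4 is expected to remain at the limit as well, with an estimate of 300000 nM and a range from 100000 nM to 1000000 nM. The expected step from compound 3 to compound 4 is accordingly a step that the limit leaves unreadable from compound 3 to compound 4, that is, none beyond the scatter.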

Compound 4, half-maximal inhibitory concentration: > 200000 nM
Compound 4: a limit, no number (the forecaster's own chance of this, stated with the estimate: 90%); the middle value lies beyond the limit too.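

In this assay compound 4 gives > 200000 nM, which is a limit, so the steps linking compound 4 with compound 1, compound 2 and compound 3 cannot be read. All four compounds share the same limit: the limit of > 200000 nM in this assay, at which 4 of the 4 values shown sit.

The compounds shown leave open how these four rank against one another and whether any group at this place gives a readable value.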